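The compounds below may be only part of what the source reports. "The series", "measured", "known", "first", "only" and "open" are said of these compounds alone.

Measured in a functional assay on MIA PaCa-2 cells (Homo sapiens) for antiproliferative activity, read by MTT assay, with a stated time of 72 h; a higher number here means a weaker inhibitor, a lower number a stronger inhibitor:
- compound 1 `Oc1ccc2ccccc2c1/C=N/NC(=S)Nc1ccccc1`: 600 nM
- compound 2 `NC(=S)N/N=C/c1ccccc1O`: > 5000 nM

For compound 2, > 5000 nM is a limit and not a number, so this compound has no exact position in the series. Compound 3 `Oc1ccccc1/C=N/NC(=S)Nc1ccccc1` departs from compound 2 by phenyl in place of hydrogen on an amide-type nitrogen. Going by the values given here, no measured step shows what this change does on its own. The expectation rests on compound 1, which gives 600 nM and so shows that a measurable value can be reached in this assay. A step beyond the scatter towards stronger inhibition is expected, estimated as an at least 2.5-fold lower number from compound 2 to compound 3 (0.39 log units; beyond the scatter). A result that again reaches the limit remains possible. For compound 3 the estimated value is 2000 nM, with an expected range of 700 nM to 5000 nM.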

Compound 3, half-maximal inhibitory concentration: 2400 nM
For compound 3 the middle estimate is 1.2-fold (0.08 log units) below the measured one; the measured number falls inside the stated range.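

In this assay, phenyl in place of hydrogen on an amide-type nitrogen gives an at least 2.0-fold lower number from compound 2 to compound 3 (0.31 log units; beyond the scatter), the only measured step at this position among the compounds shown. Compound 3 thus has an exact value while compound 2 has none, so this single change on the nitrogen is enough to bring a measurable number without the core of compound 1. For compound 2 the value is a limit and not a number, so the step is known only as a lower bound: the limit of > 5000 nM in this assay, at which 1 of the 3 values shown sits.

As far as these compounds go, whether a methyl group or a cyclohexyl ring on the same nitrogen would give a comparable step stays open. Also open, from the compounds shown here alone, is whether an amine or a carboxylic acid on the phenyl group would move the value of compound 3, 2400 nM.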